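A few compounds are considered here, and "the series" means these few. Any claim that something is new, unique, unknown or untested is made for them only; others in the source may bear on it.

Of the compounds shown here, two with the same core have been measured so far in a toxicity assay on HEK-293T cells (Homo sapiens) for inhibition, read by MTT assay, with a stated time of 24 h; a higher number here means that more compound is tolerated, a lower number that less compound is tolerated. Compound 1 (`COc1cccc(N2CCN(c3c(CO)c(=O)oc4ccccc34)CC2)c1`) gives > 50000 nM, which is a limit of the assay and not a number. Compound 2 (`O=c1oc2ccccc2c(N2CCN(c3ccccc3)CC2)c1CO`) gives > 50000 nM, which is also a limit. Compound 2 therefore stands with compound 1 at the limit of > 50000 nM in this assay, at which 2 of the 2 values shown sit.

The next compound, compound 3 (`O=c1oc2ccccc2c(N2CCN(c3ccccc3F)CC2)c1CO`), differs from compound 2 in one place: fluoro in place of hydrogen on an aromatic carbon. In short, phenyl becomes 2-fluorophenyl.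

Among the compounds with values here, only one measured step bears on this change, and it is a step that the two limits leave unreadable from compound 1 to compound 2. That step replaces methoxy with hydrogen on an aromatic carbon, so it is not the same swap, and it offers no size to carry over. Within the data shown here, with the limit of > 50000 nM in this assay, at which 2 of the 2 values shown sit, as the only evidence, no step beyond the usual scatter is expected in this assay, and no direction can be predicted. Compound 3 may well report only a limit too. The expected change is a number no higher from compound 2 to compound 3 (the limit leaves the size open). For compound 3, the estimated value is 50000 nM, with an expected range from 25000 nM to 100000 nM.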

Compound 3, half-maximal cytotoxic concentration: > 50000 nM
Compound 3 ended at the assay's limit; the forecaster's own chance of this, stated with the estimate: 80%; the middle value lies on the limit itself.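

Within the data shown here, compound 1, compound 2 and compound 3 all end at a limit of the assay and not at a number, so no step between them can be read in this assay: the limit of > 50000 nM in this assay, at which 3 of the 3 values shown sit. The compounds shown leave open how much of each compound these cells actually tolerate, and whether hydrogen, fluoro or methoxy on an aromatic carbon makes any difference to that.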